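Chloro on the pendant phenyl across two related cores

The source may hold more compounds than are shown below. What is called first, only, known or untested is meant among the compounds shown, and "the series" means these compounds.

Measured compounds:
compound 1 `Cn1c(SCC(=O)Nn2c(COc3ccc(Cl)cc3Cl)nc3ccccc3c2=O)nc(-c2ccccc2)c(C#N)c1=O`: 51.9%
compound 2 `Cn1c(SCC(=O)Nn2c(COc3ccc(Cl)cc3Cl)nc3ccccc3c2=O)nc(-c2ccc(Cl)cc2)c(C#N)c1=O`: 80.8%
compound 3 `N#Cc1c(Nc2ccccc2)nc(SCC(=O)Nn2c(COc3ccc(Cl)cc3Cl)nc3ccccc3c2=O)nc1-c1ccccc1`: 71.2%

In a functional assay on the whole organism (strain albino) for inhibition, with Rattus norvegicus as the target, read by paw edema, with stated times of 1 h and 0.5 h, at a dose of 100 mg/kg by the oral route (a higher number here means more inhibition at the dose given (going by the name of the read-out), a lower number less inhibition), compound 1 gives 51.9%. Compound 2 differs from it by chloro in place of hydrogen on an aromatic carbon and gives 80.8%, so that a number 28.9 percentage points higher from compound 1 to compound 2 (beyond the scatter). Compound 3 has a different core; how its core differs from that of compound 1 is not broken down here. In this assay compound 3 gives 71.2%, which lies within the scatter of compound 2.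

Compound 4 `N#Cc1c(Nc2ccccc2)nc(SCC(=O)Nn2c(COc3ccc(Cl)cc3Cl)nc3ccccc3c2=O)nc1-c1ccc(Cl)cc1` has not been measured. It differs from compound 3 by chloro in place of hydrogen on an aromatic carbon, the same change as that from compound 1 to compound 2. A step of the same direction is expected for compound 4, though a smaller one, because compound 3 already stands at 71.2% and the number in this assay has less room to go higher from there. The step from compound 3 to compound 4 is thus estimated as a number 13.8 percentage points higher from compound 3 to compound 4 (beyond the scatter). For compound 4 the expected value is 85%, with a range from 72% to 96%.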

Compound 4, a percentage reported as inhibition, in the whole organism at one dose (the size of the read-out at that dose, not a potency): 36.5%
The estimate for compound 4 lay 48.5 percentage points above the measured number; measured number below the stated range.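

In this assay, the change from phenyl to 4-chlorophenyl gave a number 34.7 percentage points lower from compound 3 to compound 4 (beyond the scatter), the opposite direction to its step on the core of compound 1. In these two pairs, the result of adding this chloro therefore depends on the core that carries it: the same change on two cores in this assay, a number 28.9 percentage points higher (beyond the scatter) from compound 1 to compound 2 and a number 34.7 percentage points lower (beyond the scatter) from compound 3 to compound 4, 63.6 percentage points apart, beyond the scatter of two such steps
This rests on one pair per core at a single dose, and it does not show why the direction reverses or which way the change would go on any further core.

The compounds shown leave open how a fluoro, bromo, methyl or methoxy group in the same place would behave on either core. They also leave open which part of the difference between the two cores goes with the reversal.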